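This account rests on a few compounds, and the source may have more. Where it says the series, first, only, none or still open, it means among the compounds named here.

Compound 1 `COc1cc(-c2nn(-c3cccc(NC(=O)c4cccc(C(F)(F)F)c4)c3)cc2-c2ccncc2)ccc1Cl` was tested in a functional assay on SK-MEL-28 cells (Homo sapiens) for inhibition, read by sulforhodamine B assay, with a stated time of 48 h; a lower number here means that less compound is tolerated, a higher number that more compound is tolerated. In this assay compound 1 gave only a limit, > 50000 nM, which is not a number. That reading stands at the limit of > 50000 nM in this assay, at which 1 of the 2 values shown sits. Compound 2 `O=C(Nc1cccc(-n2cc(-c3ccncc3)c(-c3ccc(Cl)c(O)c3)n2)c1)Nc1cc(C(F)(F)F)cc(C(F)(F)F)c1`, built around a urea, gave 3090 nM in this assay. Compound 3 `COc1cc(-c2nn(-c3cccc(NC(=O)Nc4ccc(Cl)c(C(F)(F)F)c4)c3)cc2-c2ccncc2)ccc1Cl` keeps the core of compound 1 and carries (4-chloro-3-(trifluoromethyl)phenyl)amino in place of 3-(trifluoromethyl)phenyl on a carbonyl carbon, which turns the amide into a urea. Compound 3 is therefore expected to be tolerated less than compound 1, with an expected step of an at least 6.2-fold lower number from compound 1 to compound 3 (0.79 log units; beyond the scatter) in this assay. The estimate for compound 3 is 8000 nM, ranging from 2000 nM to 40000 nM.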

Compound 3, concentration lethal to 50% of the cells: 19100 nM
Compound 3: the middle estimate sits 2.4-fold (0.38 log units) below what was measured, and the stated range covers the measured number.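

On a carbonyl carbon, (4-chloro-3-(trifluoromethyl)phenyl)amino in place of 3-(trifluoromethyl)phenyl gives an at least 2.6-fold lower number from compound 1 to compound 3 (0.41 log units; beyond the scatter) in this assay. This shows that this place responds to the change, which turns the amide into a urea, by more than the usual scatter. Compound 1 gives a limit, not a number: the limit of > 50000 nM in this assay, at which 1 of the 3 values shown sits.

The compounds shown leave open whether the entering nitrogen or the added chlorine accounts for the step. They also leave open how a morpholine on that ring would read.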